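Hydrogen for Methyl on a Ring Nitrogen: An Open Question

The source may report more compounds than this note shows. Statements on the series, on what has been measured and on what is new or still open speak of the compounds shown alone.

Of the compounds shown here, three sharing one core have been tested in an in vitro functional assay on cells (Fibroblast) for agonist activity at Alpha-1B adrenergic receptor (Homo sapiens); a higher number here means that more compound is needed for the effect, a lower number that less compound is needed. Compound 1 `CC(C)n1nccc1-c1ccccc1NCC1=NCCN1` gives only a limit, < 100000 nM. Compound 3 `CCn1nccc1-c1ccccc1NCC1=NCCN1` likewise gives only a limit, < 100000 nM. Compound 2 `Cc1nc(-c2ccccc2NCC2=NCCN2)n(C)n1` also gives only a limit, < 5020 nM. So compound 2 stands at no exact number: its value is a limit, and the two other values shown are limits as well (the limit of < 100000 nM in this assay, at which 2 of the 3 values shown sit; (the limit of < 5020 nM in this assay, at which 1 of the 3 values shown sits)). Going by the values given here, the one step between measured compounds, a step that the two limits leave unreadable from compound 1 to compound 3, sits at a different place, and its size cannot be read from the two limits.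

Compound 4 `Cc1n[nH]c(-c2ccccc2NCC2=NCCN2)n1` differs from compound 2 by hydrogen in place of methyl on an aromatic nitrogen. No measured step touches this place, and the only methyl-to-hydrogen step shown is unreadable. No direction beyond the scatter can be expected from these data, so the step is estimated as a step that the limit leaves unreadable from compound 2 to compound 4. Compound 4 is therefore expected near 3000 nM, within 300 nM to 30000 nM. The range is wide. Compound 2 itself gives only a limit, < 5020 nM.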

Compound 4, half-maximal effective concentration: < 5020 nM
Compound 4: only a limit was reported; the forecaster's own chance of this, stated with the estimate: 50%; the middle value is on the limit's open side.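

Compound 2 and compound 4 each give only a limit, so the step between them cannot be read: the limit of < 5020 nM in this assay, at which 2 of the 4 values shown sit. The compounds shown leave open how much of each is actually needed for the effect, and so whether hydrogen in place of methyl on an aromatic nitrogen changes anything.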